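This account rests on a few compounds, and the source may have more. Where it says the series, first, only, none or still open, it means among the compounds named here.

Compound 1, `O=C(COc1ccc(C(=O)/C=C/c2cccc(Cl)c2)cc1)N[C@H]1CCOC1=O`: in a functional assay on MGC-803 cells (Homo sapiens) for antiproliferative activity, read by MTT assay, with a stated time of 72 h (a lower number here means a stronger inhibitor, a higher number a weaker inhibitor), compound 1 gives 29100 nM.
Compound 2, `O=C(COc1ccc(C(=O)/C=C/c2cccc(Br)c2)cc1)N[C@H]1CCOC1=O`: in this assay compound 2 gives 11900 nM.
Compound 3, `O=C(COc1ccc(C(=O)/C=C/c2ccccc2)cc1)N[C@H]1CCOC1=O`: in this assay compound 3 gives only a limit, > 64000 nM.

Compound 3 is the unsubstituted parent of the three and stands at the weak end of the set: its value is a limit of the assay, not a number, and (the limit of > 64000 nM in this assay, at which 1 of the 3 values shown sits). Compound 4, `O=C(COc1ccc(C(=O)/C=C/c2cccc([N+](=O)[O-])c2)cc1)N[C@H]1CCOC1=O`, has not yet been measured. It differs from compound 3 by nitro in place of hydrogen on an aromatic carbon.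

The measured steps that bear on this change are those in which the same aromatic position carries a group rather than hydrogen. Removing chloro gave an at least 2.1-fold higher number from compound 1 to compound 3 (0.34 log units; beyond the scatter), and removing bromo gave an at least 5.3-fold higher number from compound 2 to compound 3 (0.73 log units; beyond the scatter); between the two halogens, a 2.4-fold lower number from compound 1 to compound 2 (0.39 log units; beyond the scatter). Both substituted compounds therefore give lower numbers than compound 3, and the larger group gave the lower number. The nitro group is a new kind of substituent here, so how far it follows the halogens cannot be read from the data. Still, on the weight of the steps from compound 1 and compound 2, placing a group at this position is expected to move the number below the limit of compound 3. The expected step is an at least 3.2-fold lower number from compound 3 to compound 4 (0.50 log units; beyond the scatter). Compound 4 is accordingly estimated at 20000 nM, with a range from 7000 nM to 64000 nM.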

Compound 4, half-maximal inhibitory concentration: > 64000 nM
Compound 4: no number, only a limit; the forecaster's own chance of this, stated with the estimate: 25%; at least 3.2-fold (0.50 log units) between middle value and limit.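

In this assay the value of compound 4 is a limit of the assay, as is that of compound 3, so the step between them cannot be read: the limit of > 64000 nM in this assay, at which 2 of the 4 values shown sit. For the compounds shown here, what the earlier compounds did not show is that a group at this place, meta to a large group, does not in itself bring the number down to the level of the halogen compounds: bromo replaced by nitro gives an at least 5.3-fold higher number from compound 2 to compound 4 (0.73 log units; beyond the scatter), and chloro replaced by nitro gives an at least 2.1-fold higher number from compound 1 to compound 4 (0.34 log units; beyond the scatter). Among the four compounds, only those carrying chloro or bromo give a number at all, so the drop seen with the two halogens on leaving hydrogen does not extend to nitro.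

On these data alone, how compound 3 and compound 4 stand relative to each other remains open, since neither has a number. Also open, as far as these compounds go, is whether iodo, methyl or an amine at this place would give a number as chloro and bromo do, or would stay at the limit as nitro does.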